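This account rests on a few compounds, and the source may have more. Where it says the series, first, only, none or still open, it means among the compounds named here.

Measured in a functional assay on RS4-11 cells (Homo sapiens) for inhibition, read by CCK-8 assay, with a stated time of 48 h, tested at 20 uM; a lower number here means less inhibition of growth, a higher number more inhibition of growth at the concentration tested:
- compound 1 `COc1ccc(Cc2nnc(NC(=O)/C(C#N)=C/c3ccccc3OS(=O)(=O)c3ccc(C)cc3)s2)cc1`: 70%
- compound 2 `COc1ccc(Cc2nnc(NC(=O)/C(C#N)=C/c3ccccc3OS(=O)(=O)c3ccc(OC)cc3)s2)cc1`: 78%
- compound 3 `COc1ccc(Cc2nnc(NC(=O)/C(C#N)=C/c3ccccc3OS(=O)(=O)c3ccc(Cl)cc3)s2)cc1`: 79%

Compound 1, at 70%, cannot be separated from the other two: the measured steps are a number 8 percentage points higher from compound 1 to compound 2 (within the scatter) and a number 9 percentage points higher from compound 1 to compound 3 (within the scatter). All three compounds therefore sit level in this assay.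

Compound 4 `Cc1ccc(S(=O)(=O)Oc2ccccc2/C=C(\C#N)C(=O)Nc2nnc(Cc3ccc(Cl)cc3)s2)cc1` keeps the methyl group of compound 1 and changes the other end of the molecule, turning 4-methoxybenzyl into 4-chlorobenzyl: chloro in place of methoxy on an aromatic carbon. Going by the values given here, no measured compound alters that benzyl group, so this exact change is untested. The nearest evidence is the same swap of chloro in place of methoxy on a different aromatic ring, a number 1 percentage points higher from compound 2 to compound 3 (within the scatter). The other two steps, also made on that ring, stayed within the scatter too. No step beyond the scatter is therefore expected, and the estimate is a number 4 percentage points higher from compound 1 to compound 4 (within the scatter). For compound 4 the expected value is 74%, with an estimated range from 60% to 88%.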

Compound 4, percent growth inhibition at one concentration: 69%
Beside the measured number, compound 4's estimate is 5 percentage points above it, within the range that was stated.
By their numbers in this assay, from the lowest: compounds 4, 1, 2 and 3 (each within the scatter of the next).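

Putting chloro in place of methoxy on the benzyl group, at the end of the molecule that had stayed fixed in compounds 1 to 3, gives in this assay a number 1 percentage points lower from compound 1 to compound 4 (within the scatter). This position therefore accepts either 4-methoxybenzyl or 4-chlorobenzyl without a readable shift in growth inhibition, so the earlier finding on the other aromatic ring now has a counterpart here. The swap also reads alike in both places: the same change on two cores in this assay, a number 1 percentage points higher (within the scatter) from compound 2 to compound 3 and a number 1 percentage points lower (within the scatter) from compound 1 to compound 4, 2 percentage points apart, within the scatter of two such steps

With only these two groups shown at this position, it remains open what an amine, a carboxylic acid or a longer chain would do there. On these data alone, all four compounds were also tested at a single concentration, so any differences in strength that this one reading cannot separate remain open too.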